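A few compounds are considered here, and "the series" means these few. Any claim that something is new, unique, unknown or untested is made for them only; others in the source may bear on it.

Measured so far:

Compound 1, `O=C(O)CCCSCCN1C(=O)OC[C@@H]1/C=C/[C@@H](O)Cc1cccc(C(F)(F)F)c1` — in an assay on CHO cells for displacement of a labelled ligand from prostaglandin E2 receptor EP1 subtype (Mus musculus), read by scintillation counting, with a stated time of 20 min (a higher number here means a weaker inhibitor, a lower number a stronger inhibitor), compound 1 gives > 10000 nM, a limit of the assay rather than a number.
Compound 2, `O=C(O)CCCSCCN1C(=O)SC[C@@H]1/C=C/[C@@H](O)Cc1cccc(C(F)(F)F)c1` — in this assay compound 2 gives > 10000 nM, again a limit rather than a number.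
Compound 3, `COCc1cccc(C[C@H](O)/C=C/[C@H]2COC(=O)N2CCSCCCC(=O)O)c1` — in this assay compound 3 gives > 10000 nM, also a limit and not a number.

All three measured compounds share a long acid-bearing chain and a side arm carrying a hydroxyl and a substituted benzene ring; they differ in the ring that holds the chain and in the group on the benzene. Compound 1 and compound 2 have different cores, and the difference between the two cores is not broken down here. Compound 1 and compound 3 differ in one place only: methoxymethyl in place of trifluoromethyl on an aromatic carbon. Because both sit at the limit of > 10000 nM in this assay, at which 3 of the 3 values shown sit, the step that the two limits leave unreadable from compound 1 to compound 3 cannot be read.

Compound 4, `COCc1cccc(C[C@H](O)/C=C/[C@H]2CSC(=O)N2CCSCCCC(=O)O)c1`, is not yet measured. It differs from compound 2 by methoxymethyl in place of trifluoromethyl on an aromatic carbon, the same change as that from compound 1 to compound 3, on the same place around the ring.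

Within the data shown here, with every value so far at the limit of > 10000 nM in this assay, at which 3 of the 3 values shown sit, and the only comparable step that the two limits leave unreadable from compound 1 to compound 3 unreadable, compound 4 is expected to sit at the same limit, so the expected step is a step that the limit leaves unreadable from compound 2 to compound 4. Compound 4 is estimated at 20000 nM, within 10000 nM to 100000 nM.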

Compound 4, inhibition constant: > 10000 nM
Compound 4: a limit, no number; the forecaster's own chance of this, stated with the estimate: 85%; the middle value lies beyond the limit too.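

In this assay compound 4 gives > 10000 nM, a limit and not a number, so no step can be read between compound 2 and compound 4, because both stand at that limit: the limit of > 10000 nM in this assay, at which 4 of the 4 values shown sit.

The compounds shown leave open whether methoxymethyl in place of trifluoromethyl, or the difference between the cores of compound 1 and compound 2, changes binding to this receptor at all.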